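This account rests on a few compounds, and the source may have more. Where it says the series, first, only, none or still open, it means among the compounds named here.

Measured so far in a functional assay on PC-3 cells (Homo sapiens) for cytotoxicity, read by MTT assay, with a stated time of 48 h; on this read-out lower numbers stand for stronger inhibition and higher numbers for weaker inhibition:
- compound 1, `[O-][n+]1nc(NCc2ccccc2)[n+]([O-])c2ccccc21`, gives 10700 nM.
- compound 2, `[O-][n+]1nc(NCCO)[n+]([O-])c2ccccc21`, gives 22400 nM.
- compound 3, `CCN(CC)c1n[n+]([O-])c2ccccc2[n+]1[O-]`, gives > 107000 nM.

For the measured compounds named here, the value of compound 3 is a limit of this assay, not a number; compound 3 is the one value sitting at the limit of > 107000 nM in this assay, at which 1 of the 3 values shown sits. Compound 1 and compound 2 both give numbers, and the step of a 2.1-fold higher number from compound 1 to compound 2 (0.32 log units; beyond the scatter) is modest.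

Compound 4, `C=CCNc1n[n+]([O-])c2ccccc2[n+]1[O-]`, has not been measured. The change is allylamino in place of diethylamino on an aromatic carbon. The step that bears on it is the one in the other direction, an at least 4.7-fold higher number from compound 2 to compound 3 (0.67 log units; beyond the scatter), which shows that replacing an amino bearing a hydrogen-bond donor by diethylamino moves the number at least modestly higher. Compound 4 brings back an amino with a hydrogen-bond donor, so the reverse is expected: a number lower than the limit of compound 3, in the region of compound 1 and compound 2.

Compound 4 is therefore expected to give about 20000 nM in this assay, with a plausible range of 8000 nM to 60000 nM. The implied step is expected to be an at least 5.3-fold lower number from compound 3 to compound 4 (0.72 log units; beyond the scatter).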

Compound 4, half-maximal inhibitory concentration: > 56000 nM
Compound 4: a limit, no number; the forecaster's own chance of this, stated with the estimate: 15%; middle value at least 2.8-fold (0.44 log units) from the limit.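

In this assay compound 4 sits at a limit of the assay and gives no number: the limit of > 56000 nM in this assay, at which 1 of the 4 values shown sits.

With allylamino on this aromatic carbon, between two ring nitrogen atoms, the result falls clearly short of both measured amines: an at least 2.5-fold higher number from compound 2 to compound 4 (0.39 log units; beyond the scatter) and an at least 5.2-fold higher number from compound 1 to compound 4 (0.71 log units; beyond the scatter). Compound 4 has a hydrogen-bond donor on this nitrogen, as do compound 1 and compound 2, yet only those two give numbers, so the donor alone does not secure a measurable value in this short series.

The step between compound 3 and compound 4 cannot be read, as both values are limits. Going by these compounds, it remains open whether vinyl itself or the short chain sets compound 4 apart, a question that propylamino or a longer chain ending in a hydroxyl could address.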